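Replacing the hydroxycyclohexyl group in a cell assay

The source may hold more compounds than are shown below. What is called first, only, known or untested is meant among the compounds shown, and "the series" means these compounds.

compound 1 `CC(C)(O)CNc1nc(NCc2ccc(-c3ccco3)cc2)c2ncn(C3CCCC3)c2n1` gives 21400 nM
compound 2 `OC1CCC(Nc2nc(NCc3ccc(-c4ccco4)nc3)c3ncn(C4CCCC4)c3n2)CC1` gives 180 nM

Within the data shown here, in a functional assay on HOS cells (Homo sapiens) for inhibition, with a stated time of 72 h (a lower number here means a stronger inhibitor, a higher number a weaker inhibitor), compound 2 holds the lower of the two numbers so far (180 nM), a gap beyond the usual scatter. The unmeasured compound 3 `CC(C)(O)CNc1nc(NCc2ccc(-c3ccco3)nc2)c2ncn(C3CCCC3)c2n1` has 2-hydroxy-2-methylpropyl in place of 4-hydroxycyclohexyl on a nitrogen on an aromatic ring. Among the measured compounds shown here, no measured pair isolates this change. Compound 1 also carries 2-hydroxy-2-methylpropyl and gives the higher number (21400 nM), so weaker inhibition is expected. The expected size of the change is an 8.3-fold higher number from compound 2 to compound 3 (0.92 log units; beyond the scatter) in this assay, a step beyond the scatter. Compound 3 is estimated at 1500 nM (expected range 300 nM to 9000 nM).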

Compound 3, half-maximal inhibitory concentration: 560 nM
Beside the measured number, compound 3's estimate is 2.7-fold (0.43 log units) above it; the range from low to high includes it.
By their numbers in this assay, from the lowest: compound 2; then compound 3; then compound 1.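

In this assay, the open-chain 2-hydroxy-2-methylpropyl group on this nitrogen gives only a modest loss against the 4-hydroxycyclohexyl ring, with a 3.1-fold higher number from compound 2 to compound 3 (0.49 log units; beyond the scatter) as the step, so the ring is not essential here. With 2-hydroxy-2-methylpropyl held fixed, the change to 6-(furan-2-yl)pyridin-3-yl from 4-(furan-2-yl)phenyl weighs far more, with a 38-fold lower number from compound 1 to compound 3 (1.58 log units; beyond the scatter) as its step. Nothing available explains either step.

Going by these compounds, whether a 4-aminocyclohexyl group or a longer chain ending in a carboxylic acid on this nitrogen would match compound 2 remains open.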